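Same Chain Change, Second Time Around on Shared Core

This account rests on a few compounds, and the source may have more. Where it says the series, first, only, none or still open, it means among the compounds named here.

Measured compounds:
Compound 1 `C#Cc1cccc(Nc2ncnc3cc(OCCCCCn4ccnc4[N+](=O)[O-])c(OC)cc23)c1`: 1310 nM
Compound 2 `C#Cc1cccc(Nc2ncnc3cc(OCCOCCn4ccnc4[N+](=O)[O-])c(OC)cc23)c1`: 8770 nM
Compound 3 `COc1cc2c(Nc3cccc(Br)c3)ncnc2cc1OCCCCCn1ccnc1[N+](=O)[O-]`: 5050 nM

All three were tested in a functional assay on HT-29 cells (Homo sapiens) for inhibition, read by sulforhodamine B assay, with a stated time of 72 h; a lower number here means a stronger inhibitor, a higher number a weaker inhibitor. Compound 1 gives the lowest number of the three. Compound 2 differs from it by 2-(2-nitro-1H-imidazol-1-yl)ethoxy in place of 3-(2-nitro-1H-imidazol-1-yl)propyl on a saturated chain carbon, two bonds along the chain from an oxygen on an aromatic ring, and that change brought a 6.7-fold higher number from compound 1 to compound 2 (0.83 log units; beyond the scatter). Compound 3 differs from compound 1 in a different place, by bromo in place of ethynyl on an aromatic carbon, which brought a 3.9-fold higher number from compound 1 to compound 3 (0.59 log units; beyond the scatter). Compound 3 and compound 2 lie within the usual scatter of each other, so no order between them is claimed.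

Compound 4 `COc1cc2c(Nc3cccc(Br)c3)ncnc2cc1OCCOCCn1ccnc1[N+](=O)[O-]` has not been measured. It differs from compound 3 by 2-(2-nitro-1H-imidazol-1-yl)ethoxy in place of 3-(2-nitro-1H-imidazol-1-yl)propyl on a saturated chain carbon, two bonds along the chain from an oxygen on an aromatic ring. This is the same change seen from compound 1 to compound 2, made at the same place on a core that differs by the bromo-for-ethynyl swap just described. Among these four compounds the change appears twice in all.

On the evidence of compound 1 and compound 2 alone, the step from compound 3 to compound 4 is expected to be a 5.9-fold higher number from compound 3 to compound 4 (0.77 log units; beyond the scatter), a step of about the same size as the earlier one, resting on the shown step a 6.7-fold higher number from compound 1 to compound 2 (0.83 log units; beyond the scatter). Whether a change measured once carries over to a second core is, of course, exactly what a second measurement tests. Compound 4 is estimated at 30000 nM, with a likely range from 12000 nM to 80000 nM.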

Compound 4, half-maximal inhibitory concentration: 10800 nM
For compound 4 the middle estimate is 2.8-fold (0.44 log units) above the measured one, outside the stated range (below it).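

In this assay, moving the same chain change to the core of compound 3 gave a 2.1-fold higher number from compound 3 to compound 4 (0.33 log units; beyond the scatter), so the direction carried over but the size did not: the same change on two cores in this assay, a 6.7-fold higher number (0.83 log units; beyond the scatter) from compound 1 to compound 2 and a 2.1-fold higher number (0.33 log units; beyond the scatter) from compound 3 to compound 4, 3.1-fold (0.50 log units) apart, beyond the scatter of two such steps

The bromo-for-ethynyl swap behaves in the same way, since with the 2-(2-nitro-1H-imidazol-1-yl)ethoxy group in place it gave a 1.2-fold higher number from compound 2 to compound 4 (0.09 log units; within the scatter), and the difference that the swap made with the other chain is no longer seen: the same change on two cores in this assay, a 3.9-fold higher number (0.59 log units; beyond the scatter) from compound 1 to compound 3 and a 1.2-fold higher number (0.09 log units; within the scatter) from compound 2 to compound 4, 3.1-fold (0.50 log units) apart, beyond the scatter of two such steps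

Together these results show that in this small set the effect of each change depends on what sits at the other place, so a step measured on one core is a guide to direction at best; they do not show why this happens, and with only two cores they cannot say what the change would do on a third.

Going by these compounds, it remains open whether the chain change would also keep its direction on a core carrying a chloro or a cyano group in place of the bromo or ethynyl group. On these data alone, it also remains open how the numbers would move if an amine nitrogen took the place of the chain oxygen, or if the chain were longer.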